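This account rests on a few compounds, and the source may have more. Where it says the series, first, only, none or still open, it means among the compounds named here.

The set holds three measured compounds and one that has not yet been tested. Compound 1 `CCCCCc1ccc(CCc2cc3cn([C@H]4C[C@H](O)[C@@H](CO)O4)c(=O)nc3o2)cc1`, compound 2 `CCCCCCCCCCc1cc2cn([C@H]3C[C@H](O)[C@@H](CO)O3)c(=O)nc2o1` and compound 3 `Cc1ccc(CCc2cc3cn([C@H]4C[C@H](O)[C@@H](CO)O4)c(=O)nc3o2)cc1` share a common core and differ only in the chain that hangs from it. In an ADME assay on HEL cells (Homo sapiens) for cytotoxicity, with a stated time of 3 days (a lower number here means that less compound is tolerated, a higher number that more compound is tolerated), compound 1 reaches a limit of the assay rather than a number, >= 470000 nM. Compound 2 likewise stops at a limit in this assay, >= 130000 nM. Within the data shown here, compound 3 is the one member with a read number in this assay, where compound 3 gives 540000 nM; compound 3 is thus the only point on which an estimate can rest.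

Compound 4 `CCCc1ccc(CCc2cc3cn([C@H]4C[C@H](O)[C@@H](CO)O4)c(=O)nc3o2)cc1` differs from compound 3 by ethyl in place of hydrogen on a saturated chain carbon bound to an aromatic carbon. Both measured steps that end at compound 3 are unreadable: a step that the limit leaves unreadable from compound 1 to compound 3 is cut off by the limit of >= 470000 nM in this assay, at which 1 of the 3 values shown sits, and a step that the limit leaves unreadable from compound 2 to compound 3 is cut off by the limit of >= 130000 nM in this assay, at which 1 of the 3 values shown sits. Neither step therefore shows how far a longer or shorter chain moves the tolerated concentration. In the absence of a readable step, the step from compound 3 to compound 4 is expected to be small, a 1.2-fold lower number from compound 3 to compound 4 (0.08 log units; within the scatter), within the scatter. Compound 4 is therefore estimated to give 450000 nM in this assay, with a range from 200000 nM to 900000 nM.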

Compound 4, minimum cytotoxic concentration: >= 130000 nM
Compound 4: a limit, no number (the forecaster's own chance of this, stated with the estimate: 40%); the middle value lies beyond the limit too.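

None of the steps from compound 1, compound 2 or compound 3 to compound 4 can be read, because compound 4 gives a limit and not a number: the limit of >= 130000 nM in this assay, at which 2 of the 4 values shown sit.

The compounds shown leave open whether, and how far, going from 4-methylphenyl to 4-propylphenyl moves the tolerated concentration in this assay.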